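Swapping 4-chlorophenyl for phenethyl on the sulfur

The compounds below may be only part of what the source reports. "The series", "measured", "known", "first", "only" and "open" are said of these compounds alone.

Working notes on a small series of two measured compounds and one still open. In a functional assay on SMMC-7721 cells (Homo sapiens) for inhibition, read by CCK-8 assay, with a stated time of 72 h, tested at 2 uM (a lower number here means less inhibition of growth, a higher number more inhibition of growth at the concentration tested), compound 1 (`Nc1ccccc1NC(=O)/C=C/c1ccc(CSc2ccc(Cl)cc2)cc1`) gives 15.2%, and compound 2 (`Nc1ccccc1NC(=O)c1ccc(CSc2cccc(F)c2)cc1`) gives 18.6%. Among the measured compounds shown here, compound 1 therefore stands within the scatter of compound 2, the only other number available, and no order can be read between them. For the measured compounds named here, the two compounds differ in more than one place, so they offer no single-change step to use as a guide.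

The next compound is compound 3 (`Nc1ccccc1NC(=O)/C=C/c1ccc(CSCCc2ccccc2)cc1`), which has phenethyl in place of 4-chlorophenyl on a sulfur. The rest of compound 1 stays unchanged. The data contain no direct measure of this change, so the expectation rests only on compound 1 at 15.2% and compound 2 at 18.6%. In this assay, no shift beyond the scatter is expected, and any direction is only tentatively upward. The expected size is a number 2.8 percentage points higher from compound 1 to compound 3 (within the scatter). For compound 3 the estimated value is 18%, with an expected range of 5% to 36%.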

Compound 3, percent growth inhibition at one concentration: 14.7%
Estimate against measurement, compound 3: 3.3 percentage points above; the range from low to high includes it.
By their numbers in this assay, from the lowest: compounds 3, 1 and 2 (each within the scatter of the next).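

In this assay the series gains its first single-change step, a number 0.5 percentage points lower from compound 1 to compound 3 (within the scatter), and that step lies within the scatter. On a sulfur whose other neighbours are saturated chain carbon, (4-chlorophenyl)sulfanyl and phenethylsulfanyl therefore cannot be told apart at the concentration tested, even though the entering group loses the chlorine and gains carbon between the sulfur and the aromatic ring. Nothing at hand accounts for the size of this step, and it cannot be carried beyond this one pair.

Still open, on these data alone, is whether another group on the sulfur, such as benzyl, a longer phenylpropyl chain, an aminoethyl chain or a chain ending in a carboxylic acid, would give a step beyond the scatter. Also open, as far as these compounds go, is whether phenethyl in place of an aromatic ring on the sulfur would give the same result on the core of compound 2, which carries a 3-fluorophenyl group there and has no single-change link to compound 1 or compound 3.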